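This account rests on a few compounds, and the source may have more. Where it says the series, first, only, none or still open, it means among the compounds named here.

Measured in a functional assay on HOS cells (Homo sapiens) for antiproliferative activity, read by sulforhodamine B assay; on this read-out lower numbers stand for stronger inhibition of growth and higher numbers for weaker inhibition of growth:
- compound 1 `CC[C@@H]1O[C@H](COCc2ccccc2)[C@@H](OCc2ccccc2)[C@H](OCc2ccccc2)[C@H]1O`: 34200 nM
- compound 2 `CCC[C@@H]1O[C@H](COCc2ccccc2)[C@@H](OCc2ccccc2)[C@H](OCc2ccccc2)[C@@H]1O`: > 50000 nM (a limit)
- compound 3 `CC(C)C[C@@H]1O[C@H](COCc2ccccc2)[C@@H](OCc2ccccc2)[C@H](OCc2ccccc2)[C@H]1O`: 45200 nM

Compound 2 is reported only as a limit, and this is the one such case in the set: the limit of > 50000 nM in this assay, at which 1 of the 3 values shown sits.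

Compound 3 stands level with compound 1, as a 1.3-fold higher number from compound 1 to compound 3 (0.12 log units; within the scatter) shows. Within the data shown here, these are the only two numbers available.

Next in the series is compound 4 `CC(C)C[C@@H]1O[C@H](COCc2ccccc2)[C@@H](OCc2ccccc2)[C@H](OCc2ccccc2)[C@@H]1O`, which is related to compound 3 as follows: the two compounds have the same atoms and bonds and differ only in configuration as drawn: 1 of 5 stereo elements differ; a stereocentre at a saturated ring carbon is drawn S in compound 3 and R in compound 4.

Among the measured compounds shown here, no measured step isolates a change of configuration. For the measured compounds named here, the single step available, a 1.3-fold higher number from compound 1 to compound 3 (0.12 log units; within the scatter), concerns the side chain and gives no size for an inversion at a ring carbon. With no measured basis for a shift in either direction, no step beyond the scatter is expected in this assay, and the starting point remains compound 3 at 45200 nM. The expected step is a 1.1-fold higher number from compound 3 to compound 4 (0.03 log units; within the scatter).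

The estimate for compound 4 is 48000 nM, with an expected range of 25000 nM to 90000 nM.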

Compound 4, concentration for 50% growth inhibition: 26300 nM
Estimate against measurement, compound 4: 1.8-fold (0.26 log units) above; the measured number falls inside the stated range.
By their numbers in this assay, from the lowest: compounds 4, 1 and 3 (each within the scatter of the next). At a limit, above all of these: compound 2.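

In this assay, a 1.7-fold lower number from compound 3 to compound 4 (0.24 log units; within the scatter) gives the first measured size for an inversion at this saturated ring carbon, drawn S and then R, and this step isolates that single change: the fact that compounds 3 and 4 differ only in the configuration as drawn

With the ring configuration held, methyl in place of hydrogen on a saturated chain carbon bound to two saturated chain carbons gives an at least 1.9-fold lower number from compound 2 to compound 4 (0.27 log units; that floor lies within the scatter), so only a floor can be read for this side-chain change. Compound 2 is reported as a limit and not as a number: the limit of > 50000 nM in this assay, at which 1 of the 4 values shown sits.

As far as these compounds go, whether the inversion gives a step beyond the scatter with any other side chain remains open, since one pair carries this comparison. From the compounds shown here alone, how a longer chain or an amine on the side chain would read in this assay also stays open.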